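Substituent variation on the benzothiazole-linked chromone series

This account rests on a few compounds, and the source may have more. Where it says the series, first, only, none or still open, it means among the compounds named here.

Measured so far:
compound 1 `Cc1ccc2nc(NCCCCOc3cc(O)c4c(=O)cc(-c5ccccc5)oc4c3)sc2c1`: 8.79 ug/mL
compound 2 `O=c1cc(-c2ccccc2)oc2cc(OCCCCNc3nc4ccc(F)cc4s3)cc(O)c12`: 5.25 ug/mL

Among the measured compounds shown here, in a physicochemical assay, read by spectrophotometry, with a stated time of 10 min (a higher number here means a weaker inhibitor, a lower number a stronger inhibitor), compound 2 gives the lowest of the two numbers, its nearest neighbour being compound 1, and the only step, a 1.7-fold lower number from compound 1 to compound 2 (0.22 log units; within the scatter), stays within the scatter. Compound 3 `O=c1cc(-c2ccccc2)oc2cc(OCCCCNc3nc4ccc(C(F)(F)F)cc4s3)cc(O)c12` differs from compound 2 by trifluoromethyl in place of fluoro on an aromatic carbon. No step from fluoro to trifluoromethyl is available; the one step shown, from methyl to fluoro, bears only indirectly and was small. A change beyond the scatter is therefore not expected in this assay. For compound 3 the estimate is 5.5 ug/mL, ranging from 2.5 ug/mL to 12 ug/mL, an expected step of a 1.0-fold higher number from compound 2 to compound 3 (0.02 log units; within the scatter).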

Compound 3, half-maximal inhibitory concentration: 4.95 ug/mL
For compound 3 the middle estimate is 1.1-fold (0.05 log units) above the measured one; the range from low to high includes it.
By their numbers in this assay, from the lowest: compounds 3, 2 and 1 (each within the scatter of the next).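

In this assay the change at this aromatic carbon from fluoro, 1 heavy atom, to trifluoromethyl, 4 heavy atoms, gives a 1.1-fold lower number from compound 2 to compound 3 (0.03 log units; within the scatter) and the comparison with methyl gives a 1.8-fold lower number from compound 1 to compound 3 (0.25 log units; within the scatter) so neither step leaves the scatter. Methyl, fluoro and trifluoromethyl therefore cannot be told apart at this position in this assay. No supporting measurement is available to explain this result.

As far as these compounds go, whether an amine or a carboxylic acid on the same carbon would give a step beyond the scatter remains open. The same question stands for a longer chain there.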